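An Aminophenyl Group Replaces a Chlorophenyl Group

A few compounds are considered here, and "the series" means these few. Any claim that something is new, unique, unknown or untested is made for them only; others in the source may bear on it.

Among the measured compounds shown here, in a functional assay on MCF7 cells (Homo sapiens) for cytotoxicity, read by MTT assay, with a stated time of 96 h (on this read-out higher numbers stand for weaker inhibition and lower numbers for stronger inhibition), compound 2 (`COc1cc(C(=O)c2cn(-c3cccc(Cl)c3)cc2-c2ccccc2)cc(OC)c1OC`) gives 150 nM and stands highest of the two numbers so far. Compound 1 (`COc1cc(C(=O)c2cn(-c3ccccc3)cc2-c2ccc(N)cc2)cc(OC)c1OC`) gives 9 nM there, a number lower by more than the scatter. Compound 3 (`COc1cc(C(=O)c2cn(-c3ccc(N)cc3)cc2-c2ccccc2)cc(OC)c1OC`) keeps the rest of compound 2 and carries 4-aminophenyl in place of 3-chlorophenyl on an aromatic nitrogen. For the measured compounds named here, the two measured compounds differ in more than one place, so no measured step isolates this change. Going by the values given here, the only hint comes from compound 1, which also carries a 4-aminophenyl group, though not on that nitrogen, and gives 9 nM despite that difference. On this assay a moderate move toward stronger inhibition, beyond the scatter, is therefore expected. The estimated step is a 3.8-fold lower number from compound 2 to compound 3 (0.57 log units; beyond the scatter) and it points to a lower number. Compound 3 is estimated at 40 nM (range 10 nM to 150 nM).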

Compound 3, half-maximal inhibitory concentration: 35 nM
Beside the measured number, compound 3's estimate is 1.1-fold (0.06 log units) above it; the measured number falls inside the stated range.
By their numbers in this assay, from the lowest: compound 1; then compound 3; then compound 2.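

With compound 3, the aromatic nitrogen of the five-membered ring gains its first measured single-place step: in this assay, 4-aminophenyl in place of 3-chlorophenyl gives a 4.3-fold lower number from compound 2 to compound 3 (0.63 log units; beyond the scatter). The two groups have the same heavy-atom count and the same six-membered aromatic carbon ring, but the entering group brings one hydrogen-bond donor and one hydrogen-bond acceptor, so this position responds measurably to a change confined to that ring's substituent. Nothing at hand accounts for why the number falls.

In this step the amine enters and the chlorine leaves at once. The compounds shown do not separate the two changes. They also leave open how an unsubstituted phenyl, or a hydroxyl or carboxylic acid in place of the amine, would read on that nitrogen.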